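A few compounds are considered here, and "the series" means these few. Any claim that something is new, unique, unknown or untested is made for them only; others in the source may bear on it.

Series notes. Compound 1 `NCc1cc(CO)ccc1CN(Cc1nc2ccccc2[nH]1)C1CCCc2cccnc21` gives 11 nM in a functional assay on CEM-CCRF cells for antagonist activity at C-X-C chemokine receptor type 4 (Homo sapiens), read by calcium flux; on this read-out lower numbers stand for stronger inhibition and higher numbers for weaker inhibition. Among the compounds with values here, compound 2 `NCc1cc(C(N)=O)ccc1CN(Cc1nc2ccccc2[nH]1)C1CCCc2cccnc21` gives 15 nM in this assay, the highest of the two numbers so far, though the step of a 1.4-fold higher number from compound 1 to compound 2 (0.13 log units; within the scatter) leaves the two within the scatter. Compound 3 `NCc1sccc1CN(Cc1nc2ccccc2[nH]1)C1CCCc2cccnc21` has not yet been measured. From compound 2 to compound 3 the change is a group of 7 heavy atoms (5 carbon, 1 nitrogen, 1 sulfur; one five-membered aromatic ring with 1 hetero atom) in place of a group of 11 heavy atoms (8 carbon, 2 nitrogen, 1 oxygen; one six-membered aromatic ring of carbon only), on a saturated chain carbon bound to an amine nitrogen, where the leaving group carries 1 double bond outside aromatic rings and 2 hydrogen-bond donors and the entering group 1 hydrogen-bond donor. Within the data shown here, no measured step replaces the aromatic ring at this position; the only step on record, a 1.4-fold higher number from compound 1 to compound 2 (0.13 log units; within the scatter), varies a substituent on that ring and was within the scatter, so it bears on the change only in showing that this part of the molecule accepts variation. Without direct precedent, the step expected for compound 3 is set as a modest loss, a 1.7-fold higher number from compound 2 to compound 3 (0.22 log units; within the scatter). Compound 3 is therefore estimated at 25 nM, with a range of 8 nM to 80 nM in this assay.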

Compound 3, half-maximal inhibitory concentration: 60 nM
Compound 3: middle estimate off by 2.4-fold (0.38 log units), on the low side; measured number inside the range.
By their numbers in this assay, from the lowest: compounds 1 and 2 (each within the scatter of the next); then compound 3.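

In this assay the exchange of the six-membered aromatic ring of carbon only for the five-membered aromatic ring with 1 hetero atom, on a saturated chain carbon bound to an amine nitrogen, gives a 4.0-fold higher number from compound 2 to compound 3 (0.60 log units; beyond the scatter) and a 5.5-fold higher number from compound 1 to compound 3 (0.74 log units; beyond the scatter) and both steps lie beyond the scatter. This position therefore responds measurably to a change of the ring itself, which the carbamoyl-for-hydroxymethyl step did not show, although both steps remain modest. No evidence on hand accounts for this shift.

The entering group carries neither hydroxymethyl nor carbamoyl, so the ring exchange and the loss of that substituent cannot be told apart. From the compounds shown here alone, whether a carboxylic acid or an amine on the five-membered aromatic ring would restore the lower numbers of compound 1 and compound 2 remains open.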